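Removing the phenylsulfonyl group from compound 2

This account rests on a few compounds, and the source may have more. Where it says the series, first, only, none or still open, it means among the compounds named here.

Compound 1 (`CN(C)/C(=N\C#N)C1=CC(C)(C)Oc2ccc([N+](=O)[O-])cc21`): > 31600 nM as a limit
Compound 2 (`CN(C)/C(=N\C#N)C1=CC(C)(C)Oc2ccc(S(=O)(=O)c3ccccc3)cc21`): 3310 nM as a number
Compound 3 (`CN(C)/C(=N\C#N)C1=CC(C)(C)Oc2ccc(S(C)(=O)=O)cc21`): > 31600 nM as a limit

These values come from one test (a functional assay (aorta) with Rattus norvegicus as the target; on this read-out lower numbers stand for an effect already at smaller amounts and higher numbers for an effect only at larger amounts of compound). Going by the values given here, compound 2 holds the only actual number, while the other two values are limits (the limit of > 31600 nM in this assay, at which 2 of the 3 values shown sit). The change to compound 4 (`CN(C)/C(=N\C#N)C1=CC(C)(C)Oc2ccccc21`) is hydrogen in place of phenylsulfonyl on an aromatic carbon and puts hydrogen in place of phenylsulfonyl on an aromatic carbon.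

Among the compounds with values here, two measured steps bear on this, although neither removes the group outright. Phenylsulfonyl in place of nitro on an aromatic carbon gave an at least 9.5-fold lower number from compound 1 to compound 2 (0.97 log units; beyond the scatter) and methyl in place of phenyl on a sulfonyl sulfur gave an at least 9.5-fold higher number from compound 2 to compound 3 (0.97 log units; beyond the scatter) with both lying beyond the scatter. Going by an at least 9.5-fold lower number from compound 1 to compound 2 (0.97 log units; beyond the scatter) read in reverse, a move to a higher number of similar size, beyond the scatter, is expected in this assay for this change. The estimated step runs a 9.1-fold higher number from compound 2 to compound 4 (0.96 log units; beyond the scatter) in this expectation. For compound 4 the expected value is 30000 nM with an estimated range from 8000 nM to 100000 nM around it.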

Compound 4, half-maximal effective concentration: > 31600 nM
Compound 4 gave a limit, no number (the forecaster's own chance of this, stated with the estimate: 60%); middle value at least 1.0-fold (0.02 log units) from the limit.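

Hydrogen in place of phenylsulfonyl gives an at least 9.5-fold higher number from compound 2 to compound 4 (0.97 log units; beyond the scatter) in this assay, so a bare aromatic carbon at this position does not keep the measurable effect of compound 2. The earlier compounds shown here replaced this group only with nitro or methylsulfonyl; with hydrogen added, compound 2 remains the only one of the four with an actual number. Compound 1, compound 3 and compound 4 cannot be ranked against one another, and the steps among them cannot be read: the limit of > 31600 nM in this assay, at which 3 of the 4 values shown sit.

From the compounds shown here alone, how far above this limit those three compounds lie remains open. Also open, going by these compounds, is whether a sulfonyl group carrying a butyl chain, or a phenylsulfonyl group with a methoxy group on its phenyl ring, would match or lower the number of compound 2.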